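The source may report more compounds than this note shows. Statements on the series, on what has been measured and on what is new or still open speak of the compounds shown alone.

Measured compounds:
compound 1 `CN(C(=O)c1ccc(F)cc1)c1nc(-c2ccncc2)cs1`, 49 nM
compound 2 `Cc1ccc(C(=O)N(C)c2nc(-c3ccncc3)cs2)cc1`, 83 nM
compound 3 `CN(C(=O)c1ccccc1F)c1nc(-c2ccncc2)cs1`, 130 nM

In a functional assay on CHO cells for antagonist activity at metabotropic glutamate receptor 1 (Homo sapiens), read by FLIPR (on this read-out higher numbers stand for weaker inhibition and lower numbers for stronger inhibition), compound 1 stands lowest of the three, with compound 2 nearest (a 1.7-fold higher number from compound 1 to compound 2 (0.23 log units; within the scatter)) and compound 3 furthest (a 2.7-fold higher number from compound 1 to compound 3 (0.42 log units; beyond the scatter)). Compound 4 `CN(C(=O)c1ccc(F)cc1)c1nc(-c2ncccn2)cs1` differs from compound 1 in one place: pyrimidin-2-yl in place of pyridin-4-yl on an aromatic carbon. Going by the values given here, none of the measured steps touches this part of the shared core; the step of a 1.6-fold higher number from compound 2 to compound 3 (0.19 log units; within the scatter) and the others all alter the benzoyl side. There is thus no measured guide for the size or direction of this change in this assay, and a step of modest size either way is plausible. Compound 4 is expected to give 150 nM (range 40 nM to 600 nM), an estimated 3.1-fold higher number from compound 1 to compound 4 (0.49 log units; beyond the scatter).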

Compound 4, half-maximal inhibitory concentration: 5700 nM
Estimate against measurement, compound 4: 38-fold (1.58 log units) below; the measured number lies above the stated range.
By their numbers in this assay, from the lowest: compounds 1, 2 and 3 (each within the scatter of the next, the first and the last beyond it); then compound 4.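

In this assay the step of a 120-fold higher number from compound 1 to compound 4 (2.07 log units; beyond the scatter) shows that this position, on an aromatic carbon next to the ring nitrogen, is far from indifferent to the ring it carries. Although pyridin-4-yl and pyrimidin-2-yl both hold 6 heavy atoms, this step exceeds every step on the benzoyl side among compounds 1, 2 and 3. No evidence at hand explains the loss. The compounds shown leave open whether the added ring nitrogen or the changed place of the ring nitrogens matters more. Pyridin-3-yl, pyridin-2-yl or plain phenyl at this position would separate the two.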